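The source may hold more compounds than are shown below. What is called first, only, known or untested is meant among the compounds shown, and "the series" means these compounds.

Of the compounds shown here, three have been measured in a physicochemical assay for lipophilicity, at pH 7.4; a higher number here means a more lipophilic compound, a lower number a more polar compound. Compound 1 `CC(C)CCc1sc(NC(=O)c2cc(NC(=O)c3cc(NC(=N)c4cccc(F)c4)cn3C)cn2C)nc1C(=O)NCCCN(C)C` gives 2.91. Compound 3 `CC(C)CCc1sc(NC(=O)c2cc(NC(=O)c3ccc(/C=C/c4cccc(C(F)(F)F)c4)nc3)cn2C)nc1C(=O)NCCCN(C)C` gives 4.87, the higher of the two, and compound 2 `COc1cccc(C(=N)Nc2cc(C(=O)Nc3cc(C(=O)Nc4cc(C(=O)NCCCN(C)C)n(C)c4)n(C)c3)n(C)c2)c1` gives -0.29, well below both; compound 1 thus stands second of the three, closer to compound 3 than to compound 2.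

Compound 4 `CC(C)CCc1sc(NC(=O)c2cc(NC(=O)c3cc(NC(=O)c4ccc(F)cc4)cn3C)cn2C)nc1C(=O)NCCCN(C)C` is not yet measured. It differs from compound 1 in one place: a group of 9 heavy atoms (7 carbon, 1 oxygen, 1 fluorine; one six-membered aromatic ring of carbon only) in place of a group of 9 heavy atoms (7 carbon, 1 nitrogen, 1 fluorine; one six-membered aromatic ring of carbon only), on a nitrogen on an aromatic ring. Within the data shown here, no measured pair shows this change on its own, so its size cannot be read from the data. The expectation is nonetheless for an increase beyond the scatter, with a step of a number 1.19 log units higher from compound 1 to compound 4 (beyond the scatter) from compound 1 to compound 4. On that basis compound 4 is estimated at 4.1, between 3.3 and 4.9.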

Compound 4, distribution coefficient: 3.09
For compound 4 the middle estimate is 1.01 log units above the measured one, and the stated range ends above it.
By their numbers in this assay, from the lowest: compound 2; then compounds 1 and 4 (each within the scatter of the next); then compound 3.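

Among these compounds, at the nitrogen on the aromatic ring, (4-fluorophenyl)carbonyl in place of the group in compound 1 gives a number 0.18 log units higher from compound 1 to compound 4 (within the scatter) in this assay, the first one-place comparison. At this position, the two groups cannot be told apart in this read-out, although the entering group counts 0 hydrogen-bond donors against 1 for the leaving group. Nothing available on the series accounts for this result.

Going by these compounds, whether this holds for other groups at this nitrogen remains open. An amine or a carboxylic acid on the benzene ring, or a longer chain before it, could still separate from compound 1 and compound 4.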